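Amide substituent swap on a shared core, series with level inhibition readings

The compounds below may be only part of what the source reports. "The series", "measured", "known", "first", "only" and "open" are said of these compounds alone.

Among the measured compounds shown here, compound 1 `CN(CCCn1ccnc1)C(=O)[C@@H]1CCCN1c1nccc(Nc2ccccc2)n1` is one of two compounds measured so far in an assay on isolated protein for inhibition of RAC-alpha serine/threonine-protein kinase (Homo sapiens), read by HTRF, tested at 10 uM; on this read-out lower numbers stand for less inhibition and higher numbers for more inhibition at the one concentration tested (going by the name of the read-out). In this assay compound 1 gives 0%. Compound 2 `Cc1cccc(Oc2ccnc(N3CCC[C@H]3C(=O)NCCCn3ccnc3)n2)c1` carries a different substituent on the shared core, and in this assay compound 2 gives 0%. Compound 1 stands level with compound 2 at the digits shown; the two values lie within the scatter of each other, so nothing separates them. For the measured compounds named here, no pair of measured compounds differs in one place only, so no step between measured compounds is available, and neither measured compound shows inhibition at the single concentration tested.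

Compound 3 `CN(C)CC(C)(C)CNC(=O)[C@@H]1CCCN1c1nccc(Nc2ccccc2)n1` has not yet been measured in this assay. It differs from compound 1 in one place: (2-((dimethylamino)methyl)-2-methylpropyl)amino in place of (3-(1H-imidazol-1-yl)propyl)(methyl)amino on a carbonyl carbon. With both measured compounds giving no inhibition, there is no basis for expecting this change to move the read-out beyond the scatter in either direction. The expected step is a number 2 percentage points higher from compound 1 to compound 3 (within the scatter), none beyond the scatter. Compound 3 is estimated to give 2% in this assay, with a range from -8% to 15%.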

Compound 3, a percentage reported as inhibition, at one concentration (the size of the read-out at that concentration, not a potency): 0%
Estimate against measurement, compound 3: 2 percentage points above; measured number inside the range.
By their numbers in this assay, from the lowest: compounds 1, 2 and 3 (each within the scatter of the next).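

In this assay, placing (2-((dimethylamino)methyl)-2-methylpropyl)amino in place of (3-(1H-imidazol-1-yl)propyl)(methyl)amino on a carbonyl carbon gives no change at the digits printed from compound 1 to compound 3 (within the scatter). Among the compounds shown here, this is the first comparison that isolates one place, and at this place the read-out does not separate the two substituents, although the change removes the five-membered aromatic ring and replaces a substituent with no hydrogen-bond donor by one with a hydrogen-bond donor. No accompanying measurement offers an account of this result.

With no inhibition seen on either side of the step, the series does not yet show whether any substituent on this carbonyl carbon can raise the reading beyond the scatter, and a morpholine, a carboxylic acid or a longer chain ending in a dimethylamino group would each test this on the shared core. On these data alone, it also remains open whether a change elsewhere on the shared core would give a measurable reading, against which a substituent swap at this place could be judged more informatively.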